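Replacing a Fluorophenyl Group at the Ring Amine

The source may hold more compounds than are shown below. What is called first, only, known or untested is meant among the compounds shown, and "the series" means these compounds.

Compound 1 `CC#CC(CC(=O)O)c1ccc(OCc2ccc(C(=O)N3CCN(c4ccccc4)CC3)s2)cc1` and compound 2 `CC#CC(CC(=O)O)c1ccc(OCc2ccc(C(=O)N3CCN(c4cccc(F)c4)CC3)s2)cc1` share one core and differ only in the aromatic group carried on an amine nitrogen in a ring. In a functional assay on HEK293 cells for agonist activity at Free fatty acid receptor 1 (Homo sapiens), read by fluorescence and calcium flux (a lower number here means that less compound is needed, a higher number that more compound is needed for the effect), compound 1 gives 72 nM, and compound 2 gives 97 nM. The step of a 1.3-fold higher number from compound 1 to compound 2 (0.13 log units; within the scatter) shows that exchanging hydrogen for fluoro at this aromatic carbon left the number essentially where it was. Of the two measured numbers, that of compound 2 is the higher one, yet the gap to compound 1 lies within the scatter, so the two compounds cannot be ranked against each other.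

Compound 3 `CC#CC(CC(=O)O)c1ccc(OCc2ccc(C(=O)N3CCN(c4ccccc4[N+](=O)[O-])CC3)s2)cc1` carries the change (2-nitrophenyl in place of 3-fluorophenyl on an amine nitrogen in a ring). Among the measured compounds shown here, no measured step involves a nitro group or this substitution pattern, so the only guide is the single aryl-substituent change at the same position, a 1.3-fold higher number from compound 1 to compound 2 (0.13 log units; within the scatter), which was small. Because the step of a 1.3-fold higher number from compound 1 to compound 2 (0.13 log units; within the scatter) was modest, the step of a 1.3-fold higher number from compound 2 to compound 3 (0.13 log units; within the scatter) is likewise expected to be modest, leaning toward a somewhat higher number given the larger entering group. For compound 3 the estimate in this assay is 130 nM, within a range from 50 nM to 350 nM.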

Compound 3, half-maximal effective concentration: 94 nM
Beside the measured number, compound 3's estimate is 1.4-fold (0.14 log units) above it; the range from low to high includes it.
By their numbers in this assay, from the lowest: compounds 1, 3 and 2 (each within the scatter of the next).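

In this assay, 2-nitrophenyl in place of 3-fluorophenyl on the amine nitrogen in a ring gives a 1.0-fold lower number from compound 2 to compound 3 (0.01 log units; within the scatter), while the same 2-nitrophenyl in place of a bare phenyl gives a 1.3-fold higher number from compound 1 to compound 3 (0.12 log units; within the scatter). The earlier step covered only a fluoro on the phenyl ring, whereas these steps show that a group of 9 heavy atoms with 2 hydrogen-bond acceptors, entering in place of one of 7 heavy atoms with none, still leaves the number within the scatter, so the three compounds cannot be ranked against each other. No evidence is available on why the numbers stay so close.

Going by these compounds, all three compounds carry a phenyl ring at this nitrogen, either bare or with a single group of no net charge, so it remains open what a dimethylamino group or a carboxylic acid on that ring would do. Also open, on these data alone, is whether the number would hold if the phenyl ring gave way to a saturated cyclohexyl ring or a pyridine ring, where the aromatic carbon is replaced by nitrogen.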